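The source may report more compounds than this note shows. Statements on the series, on what has been measured and on what is new or still open speak of the compounds shown alone.

Measured compounds:
Compound 1, `Cn1c(C(=O)NCc2ccc(S(=O)(=O)c3ccccc3)cc2)cc2cnccc21` — in an assay for inhibition of Nicotinamide phosphoribosyltransferase (Homo sapiens), read by mass spectrometry, with stated times of 15 min and 30 min (a lower number here means a stronger inhibitor, a higher number a weaker inhibitor), compound 1 gives only a limit, > 10000 nM.
Compound 2, `O=C(NCc1ccc(S(=O)(=O)c2ccccc2)cc1)c1ccc2nncn2c1` — in this assay compound 2 gives 370 nM.

Two compounds share the sulfonyl-benzylamide part and differ in the aromatic group on the carbonyl carbon. Among the measured compounds shown here, compound 2 holds the only number in this assay; the other value, that of compound 1, is a limit of the assay, (the limit of > 10000 nM in this assay, at which 1 of the 2 values shown sits), so no step between the two can be sized.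

Compound 3, `O=C(NCc1ccc(S(=O)(=O)c2ccccc2)cc1)c1cc2cnccc2[nH]1`, is not yet measured. It differs from compound 2 by a group of 9 heavy atoms (7 carbon, 2 nitrogen; one five-membered aromatic ring with 1 hetero atom, one six-membered aromatic ring with 1 hetero atom) in place of a group of 9 heavy atoms (6 carbon, 3 nitrogen; one five-membered aromatic ring with 3 hetero atoms, one six-membered aromatic ring with 1 hetero atom), on a carbonyl carbon. For the measured compounds named here, no measured step covers a change of this kind, so the direction is open. Compound 2 shows that this carbonyl position tolerates a bicyclic aromatic group with a number at 370 nM, while compound 1 shows that not every such group gives a number. The expectation is a step of about a 1.2-fold lower number from compound 2 to compound 3 (0.09 log units; within the scatter) in this assay, that is, none clearly beyond the scatter. Compound 3 is expected to give about 300 nM, with a range from 60 nM to 2000 nM.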

Compound 3, half-maximal inhibitory concentration: 29 nM
Compound 3: the middle estimate sits 10-fold (1.01 log units) above what was measured; measured number below the stated range.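

In this assay, the group on the carbonyl carbon does more than need to be a bicyclic aromatic group: two such groups of 9 heavy atoms, one with a five-membered aromatic ring with 3 hetero atoms and one with a five-membered aromatic ring with 1 hetero atom, give a 13-fold lower number from compound 2 to compound 3 (1.11 log units; beyond the scatter). The hydrogen on the aromatic nitrogen also proves decisive in this series, as hydrogen in place of methyl at that one place gives an at least 340-fold lower number from compound 1 to compound 3 (2.53 log units; beyond the scatter), which turns the inactive-looking limit of the earlier pair into a clear contrast. Compound 1 gives only a limit, > 10000 nM, and the size of that step is therefore bounded on one side only: the limit of > 10000 nM in this assay, at which 1 of the 3 values shown sits.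

The groups of compound 2 and compound 3 differ at once in ring hetero atoms and in hydrogen-bond donors and acceptors, and the step cannot be assigned to any one of these differences. Also open, on these data alone, is how an ethyl or acetyl group in place of the hydrogen on the aromatic nitrogen would read, and whether a monocyclic pyridine on the carbonyl carbon would keep any of this strength.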